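Carbonyl substituent swap on the piperidine nitrogen of compound 3

A few compounds are considered here, and "the series" means these few. Any claim that something is new, unique, unknown or untested is made for them only; others in the source may bear on it.

Compound 3 `Cc1ccccc1C(=O)Nc1ccc(S(=O)(=O)NC2CCN(C(=O)CCN)CC2)c2ccccc12` gives 11.3 nM in an assay on L1.2 cells for binding affinity to C-C chemokine receptor type 8 (Homo sapiens) (a lower number here means a stronger inhibitor, a higher number a weaker inhibitor), the lowest of the three numbers in hand. Compound 2 `CCOC(=O)N1CCC(NS(=O)(=O)c2ccc(OC(=O)c3ccccc3)c3ccccc23)CC1` gives 16.4 nM in this assay, which lies within the scatter of compound 3. Compound 1 `CCOC(=O)N1CCC(NS(=O)(=O)c2ccc(NCCCc3ccccc3)c3ccccc23)CC1` gives 32.1 nM in this assay, and its gap to compound 3 lies beyond the scatter. Among the measured compounds shown here, the only measured step, a 2.0-fold lower number from compound 1 to compound 2 (0.29 log units; within the scatter), concerns a substituent on an aromatic carbon and so does not bear on the present change.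

Compound 4 `Cc1ccccc1C(=O)Nc1ccc(S(=O)(=O)NC2CCN(C(=O)N3CCCCC3)CC2)c2ccccc12` differs from compound 3 in one place: piperidin-1-yl in place of 2-aminoethyl on a carbonyl carbon. For the measured compounds named here, no measured pair addresses this carbonyl carbon, so the series gives no ground for a shift in either direction; the expected step from compound 3 to compound 4 in this assay is a 1.2-fold higher number from compound 3 to compound 4 (0.09 log units; within the scatter), within the scatter. Compound 4 is accordingly estimated at 14 nM in this assay, with a range from 5 nM to 40 nM reflecting the absence of a guiding precedent.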

Compound 4, inhibition constant: 4.2 nM
Compound 4: middle estimate off by 3.3-fold (0.52 log units), on the high side; the measured number lies below the stated range.
By their numbers in this assay, from the lowest: compound 4; then compounds 3, 2 and 1 (each within the scatter of the next, the first and the last beyond it).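

In this assay, among the compounds shown here, the exchange of 2-aminoethyl for piperidin-1-yl on this carbonyl carbon gives a 2.7-fold lower number from compound 3 to compound 4 (0.43 log units; beyond the scatter) and is the first measured step at this place. The place therefore accepts a larger group with a six-membered non-aromatic ring and no hydrogen-bond donor or acceptor, and the number falls rather than rises. Nothing measured accounts for the step, which rests on this single pair.

Going by these compounds, it remains open whether the step follows from the presence of the ring or from the absence of the 2-aminoethyl group; diethylamino, morpholin-4-yl or a longer aminoalkyl chain on the same carbonyl carbon would help separate the two. Also open, on these data alone, is whether the step carries over to compounds with benzoyloxy or (3-phenylpropyl)amino on the aromatic carbon.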